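Isobutyl in place of isopropyl: working notes on compound 3

The source may report more compounds than this note shows. Statements on the series, on what has been measured and on what is new or still open speak of the compounds shown alone.

Of the compounds shown here, two have been measured so far in an ADME assay on a cell-free system (plasma, Rattus norvegicus) for metabolic stability, read by LC-MS, with a stated time of 60 min, tested at 100 uM; on this read-out higher numbers stand for a more stable compound and lower numbers for a less stable compound. Compound 1 (`Cc1ccc(C(=O)O)cc1OCCCCOc1ccc(C(=O)CC(C)C)c(O)c1C`) gives 96% in this read-out. Compound 2 (`Cc1c(OCCCCOc2ccc(F)c(C(=O)O)c2)ccc(C(=O)C(C)C)c1O`) gives 83% and is the lower of the two, with a gap to compound 1 that lies beyond the usual scatter.

The next compound, compound 3 (`Cc1c(OCCCCOc2ccc(F)c(C(=O)O)c2)ccc(C(=O)CC(C)C)c1O`), departs from compound 2 in one place: isobutyl in place of isopropyl on a carbonyl carbon describes the change, isobutyl in place of isopropyl on a carbonyl carbon. For the measured compounds named here, no measured pair isolates this change, so its size in this assay cannot be read directly from the data. Going by the values given here, the only guide is the span of the two known numbers, with compound 2 at 83% and compound 1 at 96% as its ends.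

An expected step of a number 4 percentage points higher from compound 2 to compound 3 (within the scatter) is small and upward, and it is not expected to exceed the scatter. Compound 3 is estimated at 87% with 74% to 100% as the expected range.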

Compound 3, percent of the compound remaining: 101%
Estimate against measurement, compound 3: 14 percentage points below; measured number above the stated range.
By their numbers in this assay, from the lowest: compound 2; then compounds 1 and 3 (each within the scatter of the next).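

In this assay the group on the carbonyl carbon now has a single-place reading: with the 3-carboxy-4-fluorophenyl group held constant, isobutyl in place of isopropyl gives a number 18 percentage points higher from compound 2 to compound 3 (beyond the scatter) and this step lies beyond the usual scatter. With isobutyl held constant, 3-carboxy-4-fluorophenyl in place of 5-carboxy-2-methylphenyl on an oxygen on a saturated carbon gives a number 5 percentage points higher from compound 1 to compound 3 (within the scatter) and this exchange stays within the scatter, leaving compound 2, the only one of the three carrying isopropyl, apart from the other two. Nothing available bears on why the isobutyl and isopropyl compounds differ.

Going by these compounds, whether the isobutyl-for-isopropyl step carries over to the 5-carboxy-2-methylphenyl series remains open, as a single pair cannot show whether it depends on the group at the far end of the chain. Also open, on these data alone, is how a longer chain, a cyclopropyl group or an amine on the carbonyl carbon would read in this assay and whether such groups could be told apart from isobutyl at the top of this read-out.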